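Methoxy for methyl on the aryl ring: meta case

This account rests on a few compounds, and the source may have more. Where it says the series, first, only, none or still open, it means among the compounds named here.

Measured compounds:
compound 1 `Cc1ccc(-c2oc3ccccc3c(=O)c2C)cc1`: 102 ug/mL
compound 2 `COc1ccc(-c2oc3ccccc3c(=O)c2C)cc1`: 100 ug/mL
compound 3 `Cc1cccc(-c2oc3ccccc3c(=O)c2C)c1`: 250 ug/mL

All three were run in a functional assay, read by spectrophotometry, with a stated time of 20 min; on this read-out higher numbers stand for weaker inhibition and lower numbers for stronger inhibition. Compound 1 and compound 2 differ by methoxy in place of methyl on an aromatic carbon and the step of a 1.0-fold lower number from compound 1 to compound 2 (0.01 log units; within the scatter); their values are read as the same. Compound 3 has the same atoms as compound 1, joined differently; the difference between the two cores is not broken down here. Compound 3 gives the highest number of the three, beyond the scatter from both compound 1 and compound 2.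

Compound 4 `COc1cccc(-c2oc3ccccc3c(=O)c2C)c1` has not been measured. It differs from compound 3 by methoxy in place of methyl on an aromatic carbon. This is the same kind of change as from compound 1 to compound 2, not the same: in the earlier pair the place is para to a large group, here it is meta to a large group. The change occurs twice among the compounds shown, and the one measured case, from compound 1 to compound 2, left the number essentially unchanged.

The expectation for compound 4 rests on that single measured step: because a 1.0-fold lower number from compound 1 to compound 2 (0.01 log units; within the scatter) lay within the scatter, a step of about a 1.0-fold lower number from compound 3 to compound 4 (0.02 log units; within the scatter) is expected from compound 3 to compound 4 in this assay. For the measured compounds named here, compound 4 is therefore estimated at 240 ug/mL, with a range from 120 ug/mL to 500 ug/mL, the width reflecting that only one example of the change has been measured and at a different place on the ring.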

Compound 4, half-maximal inhibitory concentration: 156 ug/mL
Compound 4: middle estimate off by 1.5-fold (0.19 log units), on the high side, within the range that was stated.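

In this assay, methoxy in place of methyl on an aromatic carbon gives a 1.6-fold lower number from compound 3 to compound 4 (0.20 log units; within the scatter), so the values of this pair are read as the same. Set beside the earlier pair, the step shows no difference between the two cores: the same change on two cores in this assay, a 1.0-fold lower number (0.01 log units; within the scatter) from compound 1 to compound 2 and a 1.6-fold lower number (0.20 log units; within the scatter) from compound 3 to compound 4, 1.6-fold (0.20 log units) apart, within the scatter of two such steps. For the compounds shown here, in this series, the swap can so far be carried between the core of compound 1 and the core of compound 3 as a change that leaves the number within the scatter, but this rests on only two pairs and does not show that the same would hold on any other core, or at any other place on the aryl ring, nor does it explain why the two steps agree.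

The compounds shown leave open whether any group on this aromatic carbon can move the number beyond the scatter, for example an amine, a carboxylic acid or a longer chain such as butoxy in place of methoxy. They also leave open what happens when the methyl on the shared core is replaced, for example by hydrogen or ethyl, since that group is the same in all four compounds.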